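The source may hold more compounds than are shown below. What is called first, only, known or untested is meant among the compounds shown, and "the series" means these compounds.

Of the compounds shown here, three built on one shared core have been measured in a functional assay on CAKI-1 cells (Homo sapiens) for inhibition, read by sulforhodamine B assay, with a stated time of 48 h; on this read-out higher numbers stand for weaker inhibition of growth and lower numbers for stronger inhibition of growth. Compound 1 `O=C(Nc1cccc(-n2cc(-c3ccncc3)c(-c3ccc(Cl)c(O)c3)n2)c1)Nc1cccc(C(F)(F)F)c1` gives 1750 nM, compound 2 `O=C(Nc1cccc(-n2cc(-c3ccncc3)c(-c3ccc(Cl)c(O)c3)n2)c1)Nc1ccc(Cl)c(Cl)c1` gives 1110 nM, and compound 3 `COc1cc(-c2nn(-c3cccc(NC(=O)Nc4ccc(Cl)c(C(F)(F)F)c4)c3)cc2-c2ccncc2)ccc1Cl` gives 992 nM, the lowest of the three numbers, though its gaps to compound 2 and to compound 1 both lie within the scatter. Among the compounds with values here, the single step between measured compounds, a 1.6-fold lower number from compound 1 to compound 2 (0.20 log units; within the scatter), concerns the group on the amide-type nitrogen, not the oxygen. Compound 4 `O=C(Nc1cccc(-n2cc(-c3ccncc3)c(-c3ccc(Cl)c(O)c3)n2)c1)Nc1ccc(Cl)c(C(F)(F)F)c1` differs from compound 3 by hydrogen in place of methyl on an oxygen on an aromatic ring. Within the data shown here, no measured step covers this change; compounds 1 and 2 carry the hydroxy group and their numbers sit within the scatter of compound 3. The step expected is therefore a 1.1-fold higher number from compound 3 to compound 4 (0.04 log units; within the scatter), nothing beyond the scatter. Compound 4 is expected to give 1100 nM, between 500 nM and 2500 nM.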

Compound 4, concentration for 50% growth inhibition: 795 nM
For compound 4 the middle estimate is 1.4-fold (0.14 log units) above the measured one; the measured number falls inside the stated range.
By their numbers in this assay, from the lowest: compounds 4, 3, 2 and 1 (each within the scatter of the next, the first and the last beyond it).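

On the oxygen of the 4-chloro-3-hydroxyphenyl group, hydroxy and methoxy read alike in this assay (a 1.2-fold lower number from compound 3 to compound 4 (0.10 log units; within the scatter)), so this change alone does not move the number beyond the scatter. Within the data shown here, on the other aromatic ring, trifluoromethyl in place of chloro also stays within the scatter (a 1.4-fold lower number from compound 2 to compound 4 (0.14 log units; within the scatter)), whereas chloro in place of hydrogen on an aromatic carbon gives the only step beyond it (a 2.2-fold lower number from compound 1 to compound 4 (0.34 log units; beyond the scatter)). Nothing available explains the size of these steps. The compounds shown leave open whether a longer chain on this oxygen, or an amine in its place, would keep the number within the scatter.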